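Cytotoxicity notes on two hydrazones and one untested analogue

A few compounds are considered here, and "the series" means these few. Any claim that something is new, unique, unknown or untested is made for them only; others in the source may bear on it.

In an ADME assay on HEL cells (Homo sapiens) for cytotoxicity (on this read-out lower numbers stand for higher toxicity in this test and higher numbers for lower toxicity in this test), compound 1 `C/C(=N\NC(=O)COc1cccc2ccccc12)c1ccc(O)cc1O` reaches only the limit of the test, > 100 ug/mL, so no number stands for it, merely (the limit of > 100 ug/mL in this assay, at which 1 of the 2 values shown sits). Compound 2 `O=C(COc1cccc2ccccc12)N/N=C/c1cccc(Br)c1` gives 100 ug/mL in this assay. Compound 3 `C/C(=N\NC(=O)COc1cccc2ccccc12)c1cccc([N+](=O)[O-])c1` is not yet measured; relative to compound 1 it carries 3-nitrophenyl in place of 2,4-dihydroxyphenyl on a carbon with a double bond to nitrogen. Going by the values given here, no measured pair differs in one place, so no step is known from the data. Nothing beyond the scatter appears across the two measured values, and the change is expected to stay within that scatter, a step of a number no higher from compound 1 to compound 3 (the limit leaves the size open). Compound 3 is estimated at 100 ug/mL, between 50 ug/mL and 200 ug/mL.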

Compound 3, minimum cytotoxic concentration: 20 ug/mL
Beside the measured number, compound 3's estimate is 5.0-fold (0.70 log units) above it, outside the stated range (below it).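

In this assay, the group on the carbon with a double bond to nitrogen proves able to shift the read-out: 3-nitrophenyl in place of 2,4-dihydroxyphenyl gives an at least 5.0-fold lower number from compound 1 to compound 3 (0.69 log units; beyond the scatter). Going by these compounds alone, this is the first step that lies beyond the scatter. Its full size stays unknown because compound 1 stands at a limit of the assay: the limit of > 100 ug/mL in this assay, at which 1 of the 3 values shown sits.

From the compounds shown here alone, the step removes the hydroxy groups and adds the nitro group together, so which of the two changes carries it stays open. Also open, going by these compounds, is how a plain phenyl or a 3-aminophenyl would read at this position.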